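Weak Cell Inhibition Across an Amide Substituent Swap

This account rests on a few compounds, and the source may have more. Where it says the series, first, only, none or still open, it means among the compounds named here.

Two measured compounds share one core and differ only in the group on an amide-type nitrogen. Compound 1 `COc1cc(-c2nnc(SCC(=O)Nc3ccccc3)n2N)cc(OC)c1OC` carries hydrogen on an aromatic carbon where compound 2 `COc1cc(-c2nnc(SCC(=O)Nc3ccc(C)cc3)n2N)cc(OC)c1OC` carries methyl. In a functional assay on HepG2 cells (Homo sapiens) for antiproliferative activity, read by MTT assay, with a stated time of 48 h (on this read-out lower numbers stand for stronger inhibition and higher numbers for weaker inhibition), compound 1 gives 49900 nM. In this assay compound 2 reaches only a limit, > 100000 nM, so no number is known for it. The step of an at least 2.0-fold higher number from compound 1 to compound 2 (0.30 log units; that floor lies within the scatter) is accordingly only a floor, not a measured size. Compound 3 `COc1ccc(CNC(=O)CSc2nnc(-c3cc(OC)c(OC)c(OC)c3)n2N)cc1OC` is not yet measured; it differs from compound 2 by 3,4-dimethoxybenzyl in place of 4-methylphenyl on an amide-type nitrogen. Within the data shown here, no measured step alters this group in a comparable way, so the only guide is the limit of > 100000 nM in this assay, at which 1 of the 2 values shown sits, for compound 2 and the weak value of compound 1. Compound 3 is expected to stay weak, the step of an at least 1.2-fold lower number from compound 2 to compound 3 (0.09 log units; that floor lies within the scatter) being of uncertain direction. Compound 3 is estimated at 80000 nM, between 30000 nM and 200000 nM.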

Compound 3, half-maximal inhibitory concentration: > 100000 nM
Compound 3: a limit, no number; the forecaster's own chance of this, stated with the estimate: 50%; middle value at least 1.2-fold (0.09 log units) from the limit.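

Compound 3 ends at a limit in this assay, > 100000 nM, so a second change on this amide-type nitrogen, with 3,4-dimethoxybenzyl and its two hydrogen-bond acceptors, also yields no number. Against phenyl the result is an at least 2.0-fold higher number from compound 1 to compound 3 (0.30 log units; that floor lies within the scatter), a floor only, while the step between the two limits cannot be read, so 3,4-dimethoxybenzyl and 4-methylphenyl cannot be ranked. Compound 1 remains the only one of these compounds with a number, and the two substituted groups both end at the limit of this read-out: the limit of > 100000 nM in this assay, at which 2 of the 3 values shown sit.

From the compounds shown here alone, whether any group at this nitrogen can bring a clearly stronger value remains open, for example a short alkyl chain or a benzyl ring carrying an amine or a carboxylic acid. Going by these compounds, how far compound 2 and compound 3 actually lie beyond their limits also stays unknown.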